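From Compound 2 to Compound 4: an Expected Potency

The source may hold more compounds than are shown below. What is called first, only, known or untested is meant among the compounds shown, and "the series" means these compounds.

Three compounds have been measured in a functional assay on CHO cells for antagonist activity at Glucagon receptor (Homo sapiens), read by cAMP accumulation, with stated times of 30 min and 45 min; a higher number here means a weaker inhibitor, a lower number a stronger inhibitor:

compound 1, `CCC[C@H](c1ccc(C(=O)NCc2nn[nH]n2)cc1)N1C(=O)C(c2cc(Cl)cc(Cl)c2)=N[C@]12CC[C@@H](C(C)(C)C)CC2`: 220 nM
compound 2, `CC(C)(C)CC[C@H](c1ccc(C(=O)NCc2nn[nH]n2)cc1)N1C(=O)C(c2cncc(Cl)c2)=N[C@]12CC[C@@H](C(C)(C)C)CC2`: 480 nM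
compound 3, `CC(C)(C)CC[C@H](c1ccc(C(=O)NCCS(=O)(=O)O)cc1)N1C(=O)C(c2cc(Cl)cc(Cl)c2)=N[C@]12CC[C@@H](C(C)(C)C)CC2`: 8500 nM

Among these three numbers compound 2 stands second highest. Its nearest neighbour is compound 1, whose lower number lies beyond the usual scatter of this assay, so compound 1 is the stronger inhibitor of the two. Furthest away is compound 3, whose far higher number also lies well beyond the scatter; compound 3 is by a wide margin the weakest inhibitor of the three.

Compound 4, `CC(C)(C)CC[C@H](c1ccc(C(=O)NCc2nn[nH]n2)cc1)N1C(=O)C(c2ccc(C(F)(F)F)cc2)=N[C@]12CC[C@@H](C(C)(C)C)CC2`, has not yet been measured. It differs from compound 2 in one place: 4-(trifluoromethyl)phenyl in place of 5-chloropyridin-3-yl on a carbon with a double bond to nitrogen. Among the measured compounds shown here, no pair of measured compounds isolates this exchange, so the step has to be judged from the spread of the three values alone.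

The step from compound 2 to compound 4 in this assay is expected to be small, most likely within the scatter, with a slight lean toward a lower number, giving a 1.2-fold lower number from compound 2 to compound 4 (0.08 log units; within the scatter). Compound 4 is accordingly estimated at 400 nM, within a range from 120 nM to 1500 nM.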

Compound 4, half-maximal inhibitory concentration: 160 nM
Estimate against measurement, compound 4: 2.5-fold (0.40 log units) above, within the range that was stated.
By their numbers in this assay, from the lowest: compounds 4 and 1 (each within the scatter of the next); then compound 2; then compound 3.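

In this assay, 4-(trifluoromethyl)phenyl in place of 5-chloropyridin-3-yl gives a 3.0-fold lower number from compound 2 to compound 4 (0.48 log units; beyond the scatter) and is the only step among the compounds shown that isolates a single place, the carbon with a double bond to nitrogen. It shows that the group on this carbon can move the number beyond the scatter while the rest of the molecule stays the same, although the step is modest in size. The entering group has 10 heavy atoms against 7 and a ring of carbon only, but nothing measured here says why the number falls.

This single exchange swaps the ring nitrogen, the chlorine and the trifluoromethyl group together, so it remains open which of these differences accounts for the step, and a plain phenyl, a 4-chlorophenyl or a 4-cyanophenyl at the same carbon would begin to separate them. From the compounds shown here alone, it is also open whether the same exchange would give a step of similar size alongside the shorter propyl chain of compound 1 or the sulfonic acid tail of compound 3.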